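This account rests on a few compounds, and the source may have more. Where it says the series, first, only, none or still open, it means among the compounds named here.

Two compounds have results so far in a functional assay on PC-3 cells (Homo sapiens) for cytotoxicity, read by MTT assay; a higher number here means a weaker inhibitor, a lower number a stronger inhibitor. There, compound 1 (`COc1cccc(CSc2nnc([C@@H](C)c3ccc4cc(OC)ccc4c3)n2-c2ccc(Cl)cc2)c1`) gives 138000 nM and compound 2 (`COc1ccc(CSc2nnc([C@@H](C)c3ccc4cc(OC)ccc4c3)n2-c2ccc(F)cc2)cc1`) gives 400000 nM as the highest of the two numbers, which makes it the weaker inhibitor by a gap beyond the usual scatter. Compound 3 (`COc1cccc(CSc2nnc([C@@H](C)c3ccc4cc(OC)ccc4c3)n2-c2ccc(F)cc2)c1`) differs from compound 2 in one place: 3-methoxyphenyl in place of 4-methoxyphenyl on a saturated chain carbon bound to a sulfur. In words, 3-methoxyphenyl stands in place of 4-methoxyphenyl on a saturated chain carbon bound to a sulfur. Among the compounds with values here, no measured pair shows this change alone, so the evidence is thin. Compound 1 carries the same 3-methoxyphenyl and gives 138000 nM as the lower number. In this assay a moderate move toward a lower number is therefore expected, with a 2.0-fold lower number from compound 2 to compound 3 (0.30 log units; within the scatter) as the estimated step. Compound 3 is expected at 200000 nM ( estimated range 80000 nM to 450000 nM).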

Compound 3, half-maximal inhibitory concentration: 211000 nM
The estimate for compound 3 lay 1.1-fold (0.02 log units) below the measured number; low and high end bracket the measured number.
By their numbers in this assay, from the lowest: compounds 1, 3 and 2 (each within the scatter of the next, the first and the last beyond it).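

In this assay, 3-methoxyphenyl in place of 4-methoxyphenyl on a saturated chain carbon bound to a sulfur gives a 1.9-fold lower number from compound 2 to compound 3 (0.28 log units; within the scatter), so this pair cannot be told apart, and the place of the methoxy group on this phenyl ring has no clear effect here. Fluoro in place of chloro on an aromatic carbon gives a 1.5-fold higher number from compound 1 to compound 3 (0.18 log units; within the scatter), so that pair cannot be told apart either. Each of these changes can now be read on its own, and neither alone moves the number beyond the scatter.

Still open, from the compounds shown here alone, is whether an amine or a carboxylic acid on that phenyl ring, or a bromo in place of the fluoro or chloro, would give a clear step in this assay. Nothing measured here explains either step.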